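The source may hold more compounds than are shown below. What is called first, only, known or untested is meant among the compounds shown, and "the series" means these compounds.

Compounds measured so far:

Compound 1 `CC1(C)OCC(Cn2cc(Cn3c4c(c5ccccc53)C(=O)c3c[n+]([O-])c5ccccc5c3C4=O)nn2)O1` — 230 nM
Compound 2 `CN(C)CCCCn1c2c(c3ccccc31)C(=O)c1c[n+]([O-])c3ccccc3c1C2=O` — 250 nM
Compound 3 `CN1CCN(CCCn2c3c(c4ccccc42)C(=O)c2c[n+]([O-])c4ccccc4c2C3=O)CC1` — 560 nM

All three share one core and differ only in the group carried on its ring nitrogen. In a functional assay on SH-SY5Y cells (Homo sapiens) for cytotoxicity, read by MTT assay, with a stated time of 72 h (on this read-out higher numbers stand for weaker inhibition and lower numbers for stronger inhibition), compound 1 gives the lowest number of the three. Compound 2 sits within the usual scatter of compound 1, so the two cannot be ordered; compound 3 lies beyond it, with a number higher than that of compound 1. Within the data shown here, the only single-point step among the measured compounds is a 2.2-fold higher number from compound 2 to compound 3 (0.35 log units; beyond the scatter), and it concerns the amine at the end of the saturated chain, not the triazole-bearing arm that compound 1 carries.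

Compound 4 `O=C1c2c[n+]([O-])c3ccccc3c2C(=O)c2c1c1ccccc1n2Cc1cn([C@@H]2O[C@H](CO)[C@@H](O)[C@H](O)[C@H]2O)nn1` takes that arm in a new direction: 3,4,5-trihydroxy-6-(hydroxymethyl)oxan-2-yl in place of (2,2-dimethyl-1,3-dioxolan-4-yl)methyl on an aromatic nitrogen. The change is 3,4,5-trihydroxy-6-(hydroxymethyl)oxan-2-yl in place of (2,2-dimethyl-1,3-dioxolan-4-yl)methyl on an aromatic nitrogen. Among the measured compounds shown here, no measured step bears on this position, so the data give no direction to expect. Compound 4 is therefore expected to land near compound 1, with a step of a 1.3-fold higher number from compound 1 to compound 4 (0.12 log units; within the scatter), and a wide range is allowed for the untested change. The estimate for compound 4 in this assay is 300 nM, between 110 nM and 850 nM.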

Compound 4, half-maximal inhibitory concentration: 880 nM
Compound 4: middle estimate off by 2.9-fold (0.47 log units), on the low side, and the stated range ends below it.
By their numbers in this assay, from the lowest: compounds 1 and 2 (each within the scatter of the next); then compounds 3 and 4 (each within the scatter of the next).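

Among these compounds, the position on the aromatic nitrogen of the five-membered aromatic ring with 3 nitrogen responds to substitution, which no earlier compound could show. In this assay, replacing (2,2-dimethyl-1,3-dioxolan-4-yl)methyl with 3,4,5-trihydroxy-6-(hydroxymethyl)oxan-2-yl gives a 3.8-fold higher number from compound 1 to compound 4 (0.58 log units; beyond the scatter), so on this read-out the sugar-like group goes with weaker inhibition than the group it replaces. The change alters several things at once, exchanging a five-membered non-aromatic ring with 2 hetero atoms and no hydrogen-bond donors for a six-membered non-aromatic ring with 1 hetero atom, hydrogen-bond donors and defined stereocentres, and nothing available here explains the shift.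

These compounds do not separate the contributions of ring size, hydroxyl groups and stereochemistry to this single step. Going by these compounds, it also remains open how an open-chain 2,3-dihydroxypropyl group, a carboxylic acid or a dimethylamino-bearing chain on the same aromatic nitrogen would read in this assay, and whether the number would then stay close to that of compound 1 or move toward that of compound 4.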